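Acetylating the aniline nitrogen of a fluorophenyl chalcone

The source may report more compounds than this note shows. Statements on the series, on what has been measured and on what is new or still open speak of the compounds shown alone.

Measured compounds:
compound 1, `Nc1ccc(C(=O)/C=C/c2ccc(O)c(F)c2)cc1-c1ccc(F)cc1`: 18100 nM
compound 2, `COc1ccc(/C=C/C(=O)c2ccc(N)c(-c3ccc(F)cc3)c2)cc1OC`: 3510 nM
compound 3, `COc1ccc(-c2cc(C(=O)/C=C/c3cccc(OC)c3OC)ccc2N)cc1OC`: 6600 nM

Three chalcones sharing an aminobiphenyl core were tested in a functional assay on CNE-2 cells (Homo sapiens) for cytotoxicity, read by sulforhodamine B assay, with a stated time of 48 h; on this read-out higher numbers stand for weaker inhibition and lower numbers for stronger inhibition. Compound 2 has the lowest of the three numbers. Compound 3 is nearest, and the gap between them lies within the scatter, so no order between the two can be read. Compound 1 is furthest, and its number is beyond the scatter from that of compound 2, so compound 1 is the weaker of those two.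

The unmeasured compound 4, `COc1ccc(/C=C/C(=O)c2ccc(NC(C)=O)c(-c3ccc(F)cc3)c2)cc1OC`, differs from compound 2 in one place: acetyl in place of hydrogen on a nitrogen on an aromatic ring. The same difference, taken one bond further out, reads amino to acetamido.

Among the compounds with values here, no pair of measured compounds shows this change, so nothing here tells how the acetyl group affects the read-out. Without such a step, the account can only expect a modest shift in this assay from compound 2 to compound 4, more likely toward a higher number than toward a lower one, and quite possibly within the scatter.

Compound 4 is therefore expected to give about 5500 nM, with a range from 1800 nM to 17000 nM. This estimate corresponds to an expected step of a 1.6-fold higher number from compound 2 to compound 4 (0.20 log units; within the scatter).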

Compound 4, half-maximal inhibitory concentration: 2740 nM
Compound 4: the middle estimate sits 2.0-fold (0.30 log units) above what was measured, within the range that was stated.
By their numbers in this assay, from the lowest: compounds 4, 2 and 3 (each within the scatter of the next, the first and the last beyond it); then compound 1.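

In this assay, within the data shown here, the change from amino to acetamido gives a 1.3-fold lower number from compound 2 to compound 4 (0.11 log units; within the scatter) and is the first step that alters only one place on the shared core. It shows that, in this one pair, the hydrogen on the nitrogen on the aromatic ring can give way to acetyl, a group of 3 heavy atoms, without any difference that can be read from the numbers. Among these compounds, nothing available here speaks to why the step is so small, and the single pair does not show whether this holds beyond compound 2 and compound 4.

Going by these compounds, whether the same acetyl step would stay as small on the core of compound 1 or on that of compound 3 remains open. Also open, on these data alone, is how this nitrogen would respond to other groups, such as a methyl, a longer acyl chain like butyryl, a methanesulfonyl group or a benzoyl group, any of which could show whether the position accepts more than acetyl.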